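From 3-fluorophenyl to 5-methylfuran-2-yl on a shared core

The compounds below may be only part of what the source reports. "The series", "measured", "known", "first", "only" and "open" are said of these compounds alone.

In a functional assay on A549 cells (Homo sapiens) for inhibition, read by sulforhodamine B assay, with a stated time of 48 h (on this read-out lower numbers stand for stronger inhibition of growth and higher numbers for weaker inhibition of growth), compound 1 `COc1ccc(/C=C/C(=O)C(=Cc2cccc(F)c2)C(=O)/C=C/c2ccc(OC)c(OC)c2)cc1OC` gives 580 nM. Compound 2 `COc1ccc(C=C(C(=O)/C=C/c2cc(OC)c(OC)c(OC)c2)C(=O)/C=C/c2cc(OC)c(OC)c(OC)c2)cc1OC` gives 370 nM, and compound 3 `CCc1ccc(C=C(C(=O)/C=C/c2ccc(O)c(OC)c2)C(=O)/C=C/c2ccc(O)c(OC)c2)cc1` gives 550 nM. All three lie within the usual scatter of one another, so compound 1 cannot be separated from either. Compound 4 `COc1ccc(/C=C/C(=O)C(=Cc2ccc(C)o2)C(=O)/C=C/c2ccc(OC)c(OC)c2)cc1OC` has 5-methylfuran-2-yl in place of 3-fluorophenyl on a double-bonded chain carbon bound to a double-bonded chain carbon. For the measured compounds named here, no measured pair shows this change alone. With compound 2 at 370 nM and compound 3 at 550 nM despite their different substituents, no step beyond the scatter is expected in this assay, in either direction. The estimated step is a 1.3-fold lower number from compound 1 to compound 4 (0.11 log units; within the scatter). Compound 4 is expected at 450 nM, with an estimated range from 180 nM to 1100 nM.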

Compound 4, concentration for 50% growth inhibition: 1310 nM
Estimate against measurement, compound 4: 2.9-fold (0.46 log units) below; the whole stated range lies below it.
By their numbers in this assay, from the lowest: compounds 2, 3 and 1 (each within the scatter of the next); then compound 4.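

In this assay, for the compounds shown here, 5-methylfuran-2-yl in place of 3-fluorophenyl gives a 2.3-fold higher number from compound 1 to compound 4 (0.35 log units; beyond the scatter), the first change here that lies beyond the scatter. It shows that the group on this double-bonded chain carbon can alter growth inhibition, and that on this core 5-methylfuran-2-yl serves less well than 3-fluorophenyl. Nothing shown here accounts for this step.

Going by these compounds, whether the step comes from the methyl or from the five-membered ring of 5-methylfuran-2-yl stays open. On these data alone, how an unsubstituted phenyl or a thiophene ring would read at this place also remains unknown.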